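Moving a Methyl on the Pendant Phenyl Ring

The source may report more compounds than this note shows. Statements on the series, on what has been measured and on what is new or still open speak of the compounds shown alone.

Compound 1, `CCC1=C(O)c2c(oc(-c3ccccc3)cc2=O)C(CC)(CC)C1=O`: > 236 uM
Compound 2, `CCC1=C(O)c2c(oc(-c3cccc(C)c3)cc2=O)C(CC)(CC)C1=O`: 49.7 uM
Compound 3, `CCC1=C(O)c2c(oc(-c3ccc(C)cc3C)cc2=O)C(CC)(CC)C1=O`: 41.2 uM

Three compounds share one core and differ only in the aryl group carried next to the ring oxygen. In a functional assay on KB cells (Homo sapiens) for antiproliferative activity, read by sulforhodamine B assay, with a stated time of 3 days (a lower number here means that less compound is needed, a higher number that more compound is needed for the effect), compound 1 gives only a limit, > 236 uM, so its value is not a number but a boundary of the assay (the limit of > 236 uM in this assay, at which 1 of the 3 values shown sits). Compound 2 gives 49.7 uM in this assay. Compound 3 gives 41.2 uM in this assay; its number and that of compound 2 lie within the scatter of each other, so no order between them can be claimed.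

Compound 4, `CCC1=C(O)c2c(oc(-c3cccc(C)c3C)cc2=O)C(CC)(CC)C1=O`, is not yet measured. It differs from compound 3 by 2,3-dimethylphenyl in place of 2,4-dimethylphenyl on an aromatic carbon.

For the measured compounds named here, two measured steps bear on this. The step of an at least 5.7-fold lower number from compound 1 to compound 3 (0.75 log units; beyond the scatter) shows that adding methyls to the phenyl ring lowers the number beyond the scatter. The step of a 1.2-fold lower number from compound 2 to compound 3 (0.08 log units; within the scatter), however, shows that shifting methyl groups between positions on an already methylated ring produced no change beyond the scatter. Since compound 4 keeps two methyls and only moves one, the expectation is a step of a 1.1-fold higher number from compound 3 to compound 4 (0.04 log units; within the scatter), within the scatter.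

Compound 4 is therefore expected to give about 45 uM, with a range from 20 uM to 100 uM.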

Compound 4, concentration for half-maximal effect: 3.1 uM
Beside the measured number, compound 4's estimate is 15-fold (1.16 log units) above it, and the stated range ends above it.
By their numbers in this assay, from the lowest: compound 4; then compounds 3 and 2 (each within the scatter of the next). At a limit, above all of these: compound 1.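

Where the methyls sit on the pendant ring matters in this assay: 2,3-dimethylphenyl and 2,4-dimethylphenyl have the same atoms and stand on the same aromatic carbon, yet the change between them gives a 13-fold lower number from compound 3 to compound 4 (1.12 log units; beyond the scatter). The earlier compounds shown here gave no sign of this, for the change from 3-methylphenyl to 2,4-dimethylphenyl gives only a 1.2-fold lower number from compound 2 to compound 3 (0.08 log units; within the scatter), whereas a methyl in place of hydrogen on the 3-methylphenyl ring, giving 2,3-dimethylphenyl, produces a 16-fold lower number from compound 2 to compound 4 (1.20 log units; beyond the scatter). The full change from phenyl to 2,3-dimethylphenyl, an at least 76-fold lower number from compound 1 to compound 4 (1.88 log units; beyond the scatter), starts from a value that is a limit and not a number: the limit of > 236 uM in this assay, at which 1 of the 4 values shown sits.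

What lies behind the large step cannot be told from these values, and the compounds shown leave open whether it would appear in any test other than this one. Also open, from the compounds shown here alone, is whether a methoxy group, a chlorine atom or an amine in place of either methyl of the 2,3-dimethylphenyl group would keep the number as low.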